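The source may report more compounds than this note shows. Statements on the series, on what has been measured and on what is new or still open speak of the compounds shown alone.

In a functional assay on HL-60 cells (Homo sapiens) for cytotoxicity, read by WST assay, with a stated time of 48 h (on this read-out higher numbers stand for an effect only at larger amounts of compound and lower numbers for an effect already at smaller amounts), compound 3 `Cc1cccc(C[C@H]2C(=O)OC[C@@H]2Cc2ccccc2)c1` gives 53000 nM, within the scatter of both compound 1 `O=C1OC[C@H](Cc2ccccc2)[C@H]1Cc1ccccc1O` at 83000 nM and compound 2 `O=C1OC[C@H](Cc2ccccc2)[C@H]1Cc1cccc(OC(F)(F)F)c1` at 34000 nM. Compound 4 `Cc1ccc(C[C@H]2C(=O)OC[C@@H]2Cc2ccccc2)cc1C` differs from compound 3 by one small change, (methyl in place of hydrogen on an aromatic carbon), methyl in place of hydrogen on an aromatic carbon. Among the measured compounds shown here, no measured step makes exactly this change. The closest evidence is two wider changes: a 1.6-fold higher number from compound 2 to compound 3 (0.19 log units; within the scatter) for methyl in place of trifluoromethoxy, and a 1.6-fold lower number from compound 1 to compound 3 (0.19 log units; within the scatter) for 3-methylphenyl in place of 2-hydroxyphenyl, both within the scatter. A step beyond the scatter is therefore not expected in this assay. The estimated step is a 1.2-fold lower number from compound 3 to compound 4 (0.07 log units; within the scatter). For compound 4 the expected value is 45000 nM, with an estimated range from 22000 nM to 90000 nM.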

Compound 4, half-maximal effective concentration: 35000 nM
Compound 4: middle estimate off by 1.3-fold (0.11 log units), on the high side; the range from low to high includes it.
By their numbers in this assay, from the lowest: compounds 2, 4, 3 and 1 (each within the scatter of the next, the first and the last beyond it).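

Among the compounds shown here, the first direct reading of this change, methyl in place of hydrogen on an aromatic carbon ortho to a methyl group and para to a large group, comes out in this assay as a 1.5-fold lower number from compound 3 to compound 4 (0.18 log units; within the scatter). At this position, then, one added methyl carbon does not move the number beyond the scatter. Nothing measured here gives a reason for this result. Still open, from the compounds shown here alone, is whether an amine, a carboxylic acid or a longer chain at this same place would give a step beyond the scatter.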